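Replacing an Imidazole with an Acetamide on a Weak Inhibitor

The compounds below may be only part of what the source reports. "The series", "measured", "known", "first", "only" and "open" are said of these compounds alone.

Compound 1, `Cc1cn(-c2ccc(Nc3nccc(-c4ccncc4)n3)cc2)cn1`, was tested in a functional assay for inhibition, with Homo sapiens as the target; a higher number here means a weaker inhibitor, a lower number a stronger inhibitor. In this assay compound 1 gives > 3000 nM, and that figure is a limit of the assay rather than a measured number. All that is known of compound 1 is that it sits at the limit of > 3000 nM in this assay, at which 1 of the 2 values shown sits. A related compound, compound 2, `Cc1cccc(Nc2nccc(-c3ccsc3)n2)c1`, was measured in the same way; in this assay compound 2 gives 3800 nM. Both results place these compounds in the weak range.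

Compound 3, `CC(=O)Nc1ccc(Nc2nccc(-c3ccncc3)n2)cc1`, has not yet been measured. It differs from compound 1 in a single place: acetamido in place of 4-methyl-1H-imidazol-1-yl on an aromatic carbon. Within the data shown here, no step between two fully measured compounds is available here, and the value of compound 1 is only a limit, which leaves the size of any change hard to anchor. The expectation is that the step that the limit leaves unreadable from compound 1 to compound 3 stays small, within the usual scatter, with compound 3 remaining a weak inhibitor. Compound 3 is therefore estimated at about 4500 nM, with a likely range from 1000 nM to 20000 nM.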

Compound 3, half-maximal inhibitory concentration: 5300 nM
Beside the measured number, compound 3's estimate is 1.2-fold (0.07 log units) below it; the measured number falls inside the stated range.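

In this assay the result for compound 1 is a limit and not a number, so the change from compound 1 to compound 3 has no size that can be read: the limit of > 3000 nM in this assay, at which 1 of the 3 values shown sits.

The compounds shown leave open whether acetamido in place of 4-methyl-1H-imidazol-1-yl strengthens inhibition, weakens it or leaves it unchanged.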